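Halogen series at the cytotoxicity limit; phenyl variant pending

This account rests on a few compounds, and the source may have more. Where it says the series, first, only, none or still open, it means among the compounds named here.

Measured compounds in a toxicity assay on WI-38 cells (Homo sapiens) for inhibition, read by MTT assay, with a stated time of 72 h; a higher number here means a weaker inhibitor, a lower number a stronger inhibitor:
- compound 1, `O=C(NCc1ccc(NC(=O)c2cc(Cl)ccc2N2CCCC2)cc1)OCc1cccnc1`: > 100000 nM, a limit of the assay
- compound 2, `O=C(NCc1ccc(NC(=O)c2cc(Br)ccc2N2CCCC2)cc1)OCc1cccnc1`: > 100000 nM, a limit of the assay
- compound 3, `O=C(NCc1ccc(NC(=O)c2cc(F)ccc2N2CCCC2)cc1)OCc1cccnc1`: > 100000 nM, a limit of the assay

All three sit at the same limit, (the limit of > 100000 nM in this assay, at which 3 of the 3 values shown sit). Compound 3 therefore stands nowhere in particular on the numbers: only a limit is known for it, and the two other values are limits as well. The steps between the measured compounds are a step that the two limits leave unreadable from compound 1 to compound 2, a step that the two limits leave unreadable from compound 1 to compound 3 and a step that the two limits leave unreadable from compound 2 to compound 3; none of them can be given a size, so they set no scale for any further change.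

Compound 4, `O=C(NCc1ccc(NC(=O)c2cc(-c3ccccc3)ccc2N2CCCC2)cc1)OCc1cccnc1`, differs from compound 3 by phenyl in place of fluoro on an aromatic carbon. The halogen steps bear on it only in that none of them brought a value out of the limit, and none of them exchanged a halogen for a ring, so their direction is not readable. The expectation is therefore that compound 4 again reports a limit in this assay, with an estimated step of a number no higher from compound 3 to compound 4 (the limit leaves the size open), that is none beyond the scatter. Compound 4 is estimated at 100000 nM, expected between 30000 nM and 300000 nM.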

Compound 4, half-maximal inhibitory concentration: > 100000 nM
Compound 4: no number, only a limit; the forecaster's own chance of this, stated with the estimate: 75%; the middle value lies on the limit itself.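

In this assay compound 4 gives > 100000 nM, a limit of the assay. The steps to compound 4 from compound 1, compound 2 and compound 3 cannot be read: the limit of > 100000 nM in this assay, at which 4 of the 4 values shown sit. The compounds shown leave open whether any change at this place gives a measurable value.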